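Replacing the 2,4-dihydroxybenzyl group of compound 3

A few compounds are considered here, and "the series" means these few. Any claim that something is new, unique, unknown or untested is made for them only; others in the source may bear on it.

Values in a functional assay on P388 cells (Mus musculus) for cytotoxicity (a lower number here means a stronger inhibitor, a higher number a weaker inhibitor), for the series
- compound 1 `Cc1cc(-c2c(F)cc3c(=O)ccn(C4CC4)c3c2F)cc(C)n1` gives 15000 nM
- compound 2 `Cc1cc(-c2c(F)cc3c(=O)c(Cc4cccc(O)c4)cn(C4CC4)c3c2F)cc(C)n1` gives 2200 nM
- compound 3 `Cc1cc(-c2c(F)cc3c(=O)c(Cc4ccc(O)cc4O)cn(C4CC4)c3c2F)cc(C)n1` gives 210 nM

Compound 3 has the lowest number of the three, with both gaps beyond the scatter. The next candidate, compound 4 `Cc1cc(-c2c(F)cc3c(=O)c(Cc4c[nH]cn4)cn(C4CC4)c3c2F)cc(C)n1`, carries this change: 1H-imidazol-4-yl in place of 2,4-dihydroxyphenyl on a saturated chain carbon bound to an aromatic carbon on the shared core. Among the measured compounds shown here, no imidazolyl analogue has been measured, so the evidence is indirect. Benzyl substitution gave a 6.8-fold lower number from compound 1 to compound 2 (0.83 log units; beyond the scatter) and a 71-fold lower number from compound 1 to compound 3 (1.85 log units; beyond the scatter) in turn, while changing only the phenyl substituents gave a 10-fold lower number from compound 2 to compound 3 (1.02 log units; beyond the scatter) as a large step. The 2,4-dihydroxyphenyl group leaves here, so a large step to a higher number is expected, estimated as a 9.5-fold higher number from compound 3 to compound 4 (0.98 log units; beyond the scatter) in this assay for now. For compound 4 the estimated value is 2000 nM within an expected range of 400 nM to 10000 nM for now.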

Compound 4, half-maximal inhibitory concentration: 390 nM
For compound 4 the middle estimate is 5.1-fold (0.71 log units) above the measured one; measured number below the stated range.
By their numbers in this assay, from the lowest: compounds 3 and 4 (each within the scatter of the next); then compound 2; then compound 1.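

At the saturated chain carbon bound to an aromatic carbon, a phenyl ring is not required in this assay: 1H-imidazol-4-yl takes the place of 2,4-dihydroxyphenyl with no step beyond the scatter (a 1.9-fold higher number from compound 3 to compound 4 (0.27 log units; within the scatter)). The hydroxyl groups of compound 3 are therefore not needed for a number in this range, as compound 4 carries none. The gain over hydrogen holds (a 38-fold lower number from compound 1 to compound 4 (1.59 log units; beyond the scatter)), and the imidazolyl group also improves on 3-hydroxyphenyl (a 5.6-fold lower number from compound 2 to compound 4 (0.75 log units; beyond the scatter)).

Open, going by these compounds, is whether a carboxylic acid, an amine or a longer chain carrying the imidazole would hold the number at this place. No data on hand bear on what lies behind these steps.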